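The Same Methyl-to-Chloro Swap on a Second Core

A few compounds are considered here, and "the series" means these few. Any claim that something is new, unique, unknown or untested is made for them only; others in the source may bear on it.

Compound 1 `CCOC(=O)c1c(-c2c(Cl)c3cc(C)ccc3oc2=O)nn(-c2cccc(C)c2)c1C(=O)OCC`: 115000 nM
Compound 2 `CCOC(=O)c1c(-c2c(Cl)c3cc(C)ccc3oc2=O)nn(-c2cccc(Cl)c2)c1C(=O)OCC`: 125000 nM
Compound 3 `CCOC(=O)c1c(-c2cc3ccc(OCC=C(C)C)cc3oc2=O)nn(-c2cccc(C)c2)c1C(=O)OCC`: 150000 nM

Of the compounds shown here, three have so far been tested in a functional assay on HeLa cells (Homo sapiens) for cytotoxicity, read by MTT assay, with a stated time of 48 h; a higher number here means a weaker inhibitor, a lower number a stronger inhibitor. Compound 1 and compound 2 share one core and differ in a single group on the phenyl ring attached to the pyrazole nitrogen: chloro in place of methyl on an aromatic carbon. In this assay compound 1 gives 115000 nM and compound 2 gives 125000 nM; the step of a 1.1-fold higher number from compound 1 to compound 2 (0.04 log units; within the scatter), so the swap left the read-out essentially unchanged here.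

Compound 3 carries a different core; how it differs from compound 1 is not broken down here. In this assay compound 3 gives 150000 nM, a value within the scatter of both compound 1 and compound 2, so the three cannot be ordered.

Compound 4 `CCOC(=O)c1c(-c2cc3ccc(OCC=C(C)C)cc3oc2=O)nn(-c2cccc(Cl)c2)c1C(=O)OCC` has not yet been measured. It stands to compound 3 as compound 2 stands to compound 1: chloro in place of methyl on an aromatic carbon. The place of the change is described in the same words for both pairs, so this is the same change made on a second core. Because a 1.1-fold higher number from compound 1 to compound 2 (0.04 log units; within the scatter) was within the scatter, the expected step from compound 3 to compound 4 is also small, a 1.1-fold higher number from compound 3 to compound 4 (0.04 log units; within the scatter), resting on that single earlier pair. Compound 4 is therefore estimated at 165000 nM in this assay, with an expected range from 90000 nM to 300000 nM.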

Compound 4, half-maximal inhibitory concentration: 110000 nM
Compound 4: the middle estimate sits 1.5-fold (0.18 log units) above what was measured, and the stated range covers the measured number.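

In this assay, among these compounds, going from the 3-methylphenyl of compound 3 to the 3-chlorophenyl of compound 4 gives a 1.4-fold lower number from compound 3 to compound 4 (0.13 log units; within the scatter), so on this second core, as on the first, the swap produces no step that can be told apart from ordinary repeat-to-repeat variation. Set side by side, the two steps agree as far as this assay can resolve: the same change on two cores in this assay, a 1.1-fold higher number (0.04 log units; within the scatter) from compound 1 to compound 2 and a 1.4-fold lower number (0.13 log units; within the scatter) from compound 3 to compound 4, 1.5-fold (0.17 log units) apart, within the scatter of two such steps. This shows that, for these two cores, the change carries over in the limited sense that neither step can be read as a real change, but it does not show that chloro and methyl are interchangeable in general. Two small steps in a single cell assay say nothing about other cores or other assays, and a small true difference could still be hidden in the scatter.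

What the compounds shown leave open is whether a clearly different group in the same place, such as an amine, a carboxylic acid or a longer chain, would shift the read-out beyond the scatter. They also leave open whether changing another part of these molecules, such as replacing the two ethyl esters with carboxylic acids, would move the numbers at all.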